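The compounds below may be only part of what the source reports. "The series", "measured", "known", "first", "only" and "open" are said of these compounds alone.

Compound 1, `CCOC(=O)CCCCCOc1cccc(CN(C(=O)c2ccc(-c3ccncc3)cc2)C(C)C)c1`, carries pyridin-4-yl on an aromatic carbon. In an ADME assay on HEK293 cells (Homo sapiens) for cytotoxicity, read by CellTiter-Glo and resazurin assay, with a stated time of 72 h (a lower number here means that less compound is needed, a higher number that more compound is needed for the effect), compound 1 gives only a limit, > 26000 nM. Compound 2, `CCOC(=O)CCCCCOc1cccc(CN(C(=O)c2ccc(-c3cccc(OC(F)(F)F)c3)cc2)C(C)C)c1`, has 3-(trifluoromethoxy)phenyl in place of pyridin-4-yl on that aromatic carbon. In this assay compound 2 likewise gives only a limit, > 26000 nM. The step that the two limits leave unreadable from compound 1 to compound 2 therefore has no readable size; what the two numbers show is the limit of > 26000 nM in this assay, at which 2 of the 2 values shown sit. For the measured compounds named here, compound 2 thus stands at the limit of this assay, alongside compound 1, and no measured step separates the two compounds.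

The unmeasured compound is compound 3, `CCOC(=O)CCCCCOc1cccc(CN(C(=O)c2ccc(-c3cccc(CC(=O)O)c3)cc2)C(C)C)c1`. It differs from compound 2 by carboxymethyl in place of trifluoromethoxy on an aromatic carbon. Going by the values given here, the only measured step, a step that the two limits leave unreadable from compound 1 to compound 2, touches the same aromatic carbon but cannot be read in size, so it gives neither a direction nor a magnitude. With both shown values resting at the limit, the reviewer expects compound 3 to remain there too, with a step that the limit leaves unreadable from compound 2 to compound 3 that stays within the scatter. The estimate for compound 3 in this assay is 40000 nM, between 20000 nM and 100000 nM.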

Compound 3, half-maximal effective concentration: > 26000 nM
Compound 3: only a limit was reported (the forecaster's own chance of this, stated with the estimate: 85%); the middle value is on the limit's open side.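

In this assay compound 3 gives > 26000 nM as a limit only. Its steps from compound 1 and from compound 2 therefore cannot be read in size. With all three compounds resting at a limit, what they leave open is whether any group on that aromatic carbon would give a measurable value in this assay at all.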